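Adding an Isopropyl to the Amide Side Chain

This account rests on a few compounds, and the source may have more. Where it says the series, first, only, none or still open, it means among the compounds named here.

Compound 1, `COc1cc(NC(C)CCCN2C(=O)CNC2(C)C)c2ncccc2c1`: in an ADME assay on a cell-free system (plasma, Homo sapiens) for metabolic stability, with Plasma (Rattus norvegicus) as the target, read by HPLC (a higher number here means that the compound lasts longer, a lower number that the compound disappears faster), compound 1 gives > 3 h, which is a limit of the assay rather than a number.
Compound 2, `COc1cc(NC(C)CCCN2C(=O)CN(C(=O)CN)C2(C)C)c2ncccc2c1`: in this assay compound 2 gives > 3 h, again a limit of the assay.

Both measured compounds therefore sit at the same ceiling, (the limit of > 3 h in this assay, at which 2 of the 2 values shown sit). Within the data shown here, compound 2 stands at that limit, and the one step that joins the measured compounds, a step that the two limits leave unreadable from compound 1 to compound 2, cannot be read in size or direction, since both ends are limits.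

Compound 3 is `COc1cc(NC(C)CCCN2C(=O)CN(C(=O)[C@H](N)C(C)C)C2(C)C)c2ncccc2c1`. It differs from compound 2 only in this way: isopropyl in place of hydrogen on a saturated chain carbon bound to an amine nitrogen and a carbonyl carbon. Among the measured compounds shown here, no measured step bears on this change in a readable way; the only step available, from compound 1 to compound 2, is hidden by the limits. With both measured compounds at the ceiling, the most reasonable expectation is that compound 3 stays there too, and the step that the limit leaves unreadable from compound 2 to compound 3 is expected to be small. Compound 3 is estimated to give 5 h in this assay, within a range from 2 h to 12 h, with a high chance that only a limit is reported.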

Compound 3, half-life in the Plasma assay: > 3 h
Compound 3 was reported as a limit; the forecaster's own chance of this, stated with the estimate: 80%; the middle value lies beyond the limit too.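

Compound 1, compound 2 and compound 3 all sit at a limit rather than at a number, so no new step between them can be read in the Plasma assay: the limit of > 3 h in the Plasma assay, at which 3 of the 3 values shown sit.

In a physicochemical assay for lipophilicity, measured as octanol-water partition (a lower number here means a more polar compound, a higher number a more lipophilic compound), compound 2 gives 2.19 and compound 3 gives 2.93.

From the compounds shown here alone, what stays open is how long each compound really lasts in the Plasma assay, and so whether the isopropyl changes that.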